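Dimethylamino in Place of Methoxy: An Expected Step

The source may report more compounds than this note shows. Statements on the series, on what has been measured and on what is new or still open speak of the compounds shown alone.

Of the compounds shown here, two have been measured in an assay on CHO cells for positive allosteric modulation of adenosine receptor A1 (Homo sapiens), read by ERK phosphorylation, tested at 3 uM; on this read-out lower numbers stand for a stronger effect and higher numbers for a weaker effect at the one concentration tested. Among the compounds with values here, compound 1 `CN(C)c1ccc(-c2cc(C(=O)c3ccccc3)c(N)s2)cc1` gives 50%, and compound 2 `COc1ccc(-c2cc(C(=O)c3ccc(Cl)cc3)c(N)s2)cc1` gives 51%; the gap between them lies within the usual scatter, so compound 2 stands level with compound 1 on the numbers so far. Compound 3 `CN(C)c1ccc(-c2cc(C(=O)c3ccc(Cl)cc3)c(N)s2)cc1` differs from compound 2 by dimethylamino in place of methoxy on an aromatic carbon. Within the data shown here, no measured pair isolates this change, as compound 1 and compound 2 differ in two places. Because compound 2 gives 51% and compound 1 gives 50%, the expected step in this assay is a number 1 percentage points lower from compound 2 to compound 3 (within the scatter), nothing beyond the scatter. Compound 3 is therefore estimated at 50%, between 36% and 64%.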

Compound 3, a percentage reported as activity, at one concentration (the size of the read-out at that concentration, not a potency): 56%
The estimate for compound 3 lay 6 percentage points below the measured number, within the range that was stated.
By their numbers in this assay, from the lowest: compounds 1, 2 and 3 (each within the scatter of the next).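

Dimethylamino in place of methoxy on an aromatic carbon, para to a large group, gives a number 5 percentage points higher from compound 2 to compound 3 (within the scatter) in this assay and so offers the first direct comparison of the two groups, which stand level at this position. Chloro in place of hydrogen on an aromatic carbon, now also seen alone, gives a number 6 percentage points higher from compound 1 to compound 3 (within the scatter) and likewise leaves the compounds level. Nothing available explains either result.

On these data alone, whether a primary amine, a carboxylic acid or a longer alkoxy chain in place of dimethylamino would move the number beyond the scatter remains open. So does the outcome of bromo or fluoro in place of chloro.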